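Swapping the acyl cap on an aminotriazolopyrimidine core

A few compounds are considered here, and "the series" means these few. Any claim that something is new, unique, unknown or untested is made for them only; others in the source may bear on it.

Measured compounds:
Compound 1, `Nc1ccc(C(=O)Nc2nc(-c3ccccc3)nc3c2nnn3Cc2ccccc2)cc1`: 926 nM
Compound 2, `Nc1nc(-c2ccccc2)nc2c1nnn2Cc1ccccc1`: 4220 nM

Of the compounds shown here, two have been tested in an assay on CHO cells for displacement of a labelled ligand from adenosine receptor A3 (Homo sapiens), read by scintillation counting; a higher number here means a weaker inhibitor, a lower number a stronger inhibitor. Compound 1 (`Nc1ccc(C(=O)Nc2nc(-c3ccccc3)nc3c2nnn3Cc2ccccc2)cc1`) carries a (4-aminophenyl)carbonyl group on the nitrogen attached to the shared core, and in this assay compound 1 gives 926 nM. Among the compounds with values here, compound 2 (`Nc1nc(-c2ccccc2)nc2c1nnn2Cc1ccccc1`) has a plain hydrogen there instead, and compound 2 gives 4220 nM, the higher of the two numbers; the only step measured so far, a 4.6-fold higher number from compound 1 to compound 2 (0.66 log units; beyond the scatter), separates it from compound 1.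

Compound 3 (`O=C(Nc1nc(-c2ccccc2)nc2c1nnn2Cc1ccccc1)c1cccc(F)c1`) is the next step from compound 2: (3-fluorophenyl)carbonyl in place of hydrogen on a nitrogen on an aromatic ring. This is the same kind of change as the measured step, only with a different cap on the same nitrogen. Within the data shown here, the one step available, a 4.6-fold higher number from compound 1 to compound 2 (0.66 log units; beyond the scatter), shows that placing an aryl carbonyl cap on this nitrogen lowered the number by a modest, clearly resolved amount. On that basis the expectation for compound 3 is a lower number than for compound 2, of roughly similar size, expressed as a 6.0-fold lower number from compound 2 to compound 3 (0.78 log units; beyond the scatter). The estimate for compound 3 in this assay is 700 nM, expected to fall between 180 nM and 2800 nM.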

Compound 3, inhibition constant: 5810 nM
For compound 3 the middle estimate is 8.3-fold (0.92 log units) below the measured one; the measured number lies above the stated range.
By their numbers in this assay, from the lowest: compound 1; then compounds 2 and 3 (each within the scatter of the next).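

In this assay, the (3-fluorophenyl)carbonyl cap on this nitrogen gives a reading that cannot be told apart from that of the uncapped amino group (a 1.4-fold higher number from compound 2 to compound 3 (0.14 log units; within the scatter)), so the presence of an aryl carbonyl cap does not on its own bring the lower number seen with compound 1. The group on the carbonyl carbon matters instead: with 3-fluorophenyl in place of 4-aminophenyl there is a clear difference (a 6.3-fold higher number from compound 1 to compound 3 (0.80 log units; beyond the scatter)), and among these three compounds only the 4-aminophenyl cap stands apart from the uncapped compound. No measured evidence is available to explain this difference.

This swap changes two things at once, the loss of the amino group and the arrival of the fluorine, so the compounds shown cannot say which of them accounts for the difference, or whether the place of each substituent on the ring matters. A plain phenyl, a 3-aminophenyl or a 4-fluorophenyl on the same carbonyl carbon would begin to separate these possibilities, and a methyl there would test whether an aromatic ring on the cap matters at all.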